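Trading one oxygen for sulfur in compound 1

The compounds below may be only part of what the source reports. "The series", "measured", "known", "first", "only" and "open" are said of these compounds alone.

In a functional assay on DU-145 cells (Homo sapiens) for cytotoxicity, read by MTT assay, with a stated time of 72 h (on this read-out higher numbers stand for an effect only at larger amounts of compound and lower numbers for an effect already at smaller amounts), compound 1 (`CCc1cccc2c(OC)c(-c3occ(C)c3C(=O)OC)ccc12`) gives 2.2 ug/mL and compound 3 (`CCOC(=O)c1c(C)coc1-c1ccc2c(CC)cccc2c1OC`) gives 2.2 ug/mL as well, so the two stand level. Compound 2 (`CCOc1c(-c2occ(C)c2C(=O)O)ccc2c(CC)cccc12`) reads > 10 ug/mL and this is a limit of the assay, not a number. Compound 4 (`CCc1cccc2c(OC)c(-c3occ(C)c3C(=S)OC)ccc12`) is still unmeasured and differs from compound 1 by one change (a group of 4 heavy atoms (2 carbon, 1 oxygen, 1 sulfur; no ring) in place of a group of 4 heavy atoms (2 carbon, 2 oxygen; no ring), on an aromatic carbon) on an aromatic carbon. Going by the values given here, the only measured step touching this group is no change at the digits printed from compound 1 to compound 3 (within the scatter) and it concerns the chain end, leaving the exchange of oxygen for sulfur untested. Expected on this thin basis is no change at the digits printed from compound 1 to compound 4 (within the scatter) in this assay with no shift beyond the scatter in either direction. For compound 4 the estimated value is 2.2 ug/mL with an expected range from 0.8 ug/mL to 6.5 ug/mL around it.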

Compound 4, concentration for half-maximal effect: 5.7 ug/mL
The estimate for compound 4 lay 2.6-fold (0.41 log units) below the measured number; the measured number falls inside the stated range.
By their numbers in this assay, from the lowest: compounds 1 and 3 (each within the scatter of the next); then compound 4. At a limit, above all of these: compound 2.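

In this assay, going by these compounds alone, the methoxycarbonyl group tolerates no free exchange: putting sulfur in place of the carbonyl oxygen gives a 2.6-fold higher number from compound 1 to compound 4 (0.41 log units; beyond the scatter), the first step at this position that lies beyond the scatter. The comparison with the ethyl ester gives the same size, a 2.6-fold higher number from compound 3 to compound 4 (0.41 log units; beyond the scatter), while the longer chain end of compound 3 changed nothing at the digits printed. So this position responds to the atom exchanged, though only modestly. Nothing shown gives a measured reason for this shift. On these data alone, whether an amide or a nitrile on this aromatic carbon would stay level with the esters remains open.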